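Cytotoxicity limits across three aryl variants and a fourth

The compounds below may be only part of what the source reports. "The series", "measured", "known", "first", "only" and "open" are said of these compounds alone.

Compound 1 `Cc1cc(C)c(Oc2cc(Nc3ccc(C#N)cc3)ncc2C(=O)NCc2cn(Cc3cccc([N+](=O)[O-])c3)nn2)c(C)c1`: >= 156000 nM
Compound 2 `Cc1cc(C)c(Oc2cc(Nc3ccc(C#N)cc3)ncc2C(=O)NCc2cn(Cc3ccc(F)cc3)nn2)c(C)c1`: >= 153000 nM
Compound 3 `Cc1cc(C)c(Oc2cc(Nc3ccc(C#N)cc3)ncc2C(=O)NCc2cn(Cc3ccccc3C)nn2)c(C)c1`: >= 164000 nM

In an ADME assay on MT4 cells (Homo sapiens) for cytotoxicity, read by MTT assay, with a stated time of 5 days (a higher number here means that more compound is tolerated, a lower number that less compound is tolerated), every one of these values is a limit of the assay rather than a number. Compound 3 stands at a limit (the limit of >= 164000 nM in this assay, at which 1 of the 3 values shown sits). Compound 1 stands at a limit (the limit of >= 156000 nM in this assay, at which 1 of the 3 values shown sits). Compound 2 stands at a limit (the limit of >= 153000 nM in this assay, at which 1 of the 3 values shown sits).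

Compound 4 `Cc1ccc(Cn2cc(CNC(=O)c3cnc(Nc4ccc(C#N)cc4)cc3Oc3c(C)cc(C)cc3C)nn2)cc1` differs from compound 3 by 4-methylphenyl in place of 2-methylphenyl on a saturated chain carbon bound to an aromatic nitrogen. The measured steps that bear on this change are a step that the two limits leave unreadable from compound 1 to compound 2, a step that the two limits leave unreadable from compound 1 to compound 3 and a step that the two limits leave unreadable from compound 2 to compound 3; each alters the group on the same saturated chain carbon, and none has a readable size. No step beyond the scatter is therefore expected in this assay in either direction. Compound 4 is expected to show a step of an at least 1.0-fold lower number from compound 3 to compound 4 (0.01 log units; that floor lies within the scatter), most likely again as a limit, with an estimate of 160000 nM between 60000 nM and 300000 nM.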

Compound 4, half-maximal cytotoxic concentration: 165000 nM
For compound 4 the middle estimate is 1.0-fold (0.01 log units) below the measured one; the range from low to high includes it.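

In this assay, no step can be read from compound 1, compound 2 or compound 3 to compound 4, as the first three values are limits. The compounds shown leave open whether 2-methylphenyl and 4-methylphenyl differ at all in this assay.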